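The source may report more compounds than this note shows. Statements on the series, on what has been measured and on what is new or still open speak of the compounds shown alone.

In an in vitro ADME assay on microsomes from liver (Homo sapiens) for metabolic stability, tested at 1 uM (on this read-out lower numbers stand for a shorter-lived compound and higher numbers for a longer-lived compound), two compounds sharing one core have been measured so far. Compound 1 `COc1cccc(CN2C(=O)C(C3=NS(=O)(=O)c4cc(NS(C)(=O)=O)ccc4N3)=C(O)[C@@H]3[C@H]4CC[C@H](C4)[C@@H]32)c1`, carrying 3-methoxyphenyl, gives > 1 h, which is a limit of the assay and not a number. Compound 2 `CS(=O)(=O)Nc1ccc2c(c1)S(=O)(=O)N=C(C1=C(O)[C@@H]3[C@H]4CC[C@H](C4)[C@@H]3N(Cc3ccc(F)c(Cl)c3)C1=O)N2`, carrying 3-chloro-4-fluorophenyl, gives > 1 h, again only a limit. Its place is thus known only through (the limit of > 1 h in this assay, at which 2 of the 2 values shown sit). Compound 3 `CS(=O)(=O)Nc1ccc2c(c1)S(=O)(=O)N=C(C1=C(O)[C@@H]3[C@H]4CC[C@H](C4)[C@@H]3N(Cc3ccc(F)c(F)c3F)C1=O)N2` has 2,3,4-trifluorophenyl in place of 3-chloro-4-fluorophenyl on a saturated chain carbon bound to an amide-type nitrogen in a ring. Going by the values given here, the only measured step at this place is a step that the two limits leave unreadable from compound 1 to compound 2, which offers no size or direction to carry over. In this assay, nothing beyond the usual scatter is therefore expected, and the estimated move is a step that the limit leaves unreadable from compound 2 to compound 3. For compound 3 the expected half-life is 1.5 h, within an estimated range of 0.7 h to 3 h.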

Compound 3, half-life: > 1 h
Compound 3 ended at the assay's limit (the forecaster's own chance of this, stated with the estimate: 75%); the middle value does not contradict the limit.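

No step among compound 1, compound 2 and compound 3 can be read in this assay, since each result is a limit and not a number: the limit of > 1 h in this assay, at which 3 of the 3 values shown sit.

What stays open is the actual half-life of each of these compounds, and whether their different aromatic groups change it at all.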